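The source may report more compounds than this note shows. Statements on the series, on what has been measured and on what is new or still open speak of the compounds shown alone.

Measured so far:
- compound 1 `COc1ccc2cc(C(C)c3nnc4n3N=C(c3ccc(Cl)cc3Cl)CS4)ccc2c1`, in a functional assay on HCT-116 cells (Homo sapiens) for inhibition, read by sulforhodamine B assay, with a stated time of 72 h (a lower number here means a stronger inhibitor, a higher number a weaker inhibitor), compound 1 gives 14000 nM
- compound 2 `Cc1ccc(C2=Nn3c(nnc3C(C)c3ccc(-c4ccccc4)c(F)c3)SC2)cc1`, in this assay compound 2 gives 4800 nM

Compound 2 holds the lower of the two numbers measured in this assay; its nearest neighbour is compound 1, whose higher number lies beyond the scatter of the measurement. For the measured compounds named here, the two compounds differ in more than one place, so no single structural step connects them and nothing is said here about what drives the gap.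

Compound 3 `CC(c1ccc(-c2ccccc2)c(F)c1)c1nnc2n1N=C(c1ccc(F)cc1)CS2` is the next compound of the series and is not yet measured. Its structure differs from compound 2 in one place: fluoro in place of methyl on an aromatic carbon. The change keeps the size of the group and adds no donor or acceptor; it is a swap of one small substituent for another on the outer ring.

Going by the values given here, no step between measured compounds shows what such a swap does in this assay. The expectation for the step from compound 2 to compound 3 is therefore a 1.0-fold higher number from compound 2 to compound 3 (0.02 log units; within the scatter), that is, no change beyond the scatter in either direction. On that basis compound 3 is estimated at 5000 nM in this assay, with a range from 2000 nM to 12000 nM.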

Compound 3, half-maximal inhibitory concentration: 10500 nM
Estimate against measurement, compound 3: 2.1-fold (0.32 log units) below; low and high end bracket the measured number.
By their numbers in this assay, from the lowest: compound 2; then compounds 3 and 1 (each within the scatter of the next).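

In this assay the outer ring does not tolerate every small swap equally: the change from 4-methylphenyl to 4-fluorophenyl gives a 2.2-fold higher number from compound 2 to compound 3 (0.34 log units; beyond the scatter), a modest step but one that lies beyond the scatter. For the compounds shown here, as the first single-place step, it shows that at this position, para to a large group, methyl gives the lower number of the two, although neither group brings a hydrogen-bond donor or acceptor. No measurement at hand accounts for the step, so it stands as an observation on this one pair.

Only methyl and fluoro have been compared at this position, so the compounds shown do not tell how an amine, a carboxylic acid or a longer chain such as propyl would read there, nor whether the number keeps rising or falling along any such set of groups. Also open, on these data alone, is whether the same swap gives a step of similar size when the rest of the molecule is different, as one pair cannot separate a general trend at this position from a result specific to compound 2 and compound 3.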